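Shifting a Ring Nitrogen in a Weakly Active Series

The source may hold more compounds than are shown below. What is called first, only, known or untested is meant among the compounds shown, and "the series" means these compounds.

Compound 2 `Cc1c(-c2cc(Cl)cc(Cl)c2)c(C(=O)O)nn1-c1nc(-c2ccncc2)c(SC(C)C)s1` was tested in a functional assay on BJAB cells (Homo sapiens) for antiproliferative activity, with a stated time of 4 days (on this read-out lower numbers stand for an effect already at smaller amounts and higher numbers for an effect only at larger amounts of compound), where it is reported as "not active" (no number reported), with no number attached. Two relatives set the scale: compound 1 `Cc1nn(-c2nc(-c3ccc(Cl)c(Cl)c3)c(SC(C)C)s2)c(C(=O)O)c1Cc1ccccc1[N+](=O)[O-]` gives 20000 nM, and compound 3 `COc1cc(C#N)cc(-c2c(C)nn(-c3nc(-c4ccc(Cl)c(Cl)c4)c(SC(C)C)s3)c2C(=O)O)c1` gives 5200 nM, so that a 3.8-fold lower number from compound 1 to compound 3 (0.59 log units; beyond the scatter). Compound 4 `Cc1c(-c2cc(Cl)cc(Cl)c2)c(C(=O)O)nn1-c1nc(-c2cccnc2)c(SC(C)C)s1` keeps every atom of compound 2 but joins them differently: pyridin-3-yl in place of pyridin-4-yl on an aromatic carbon. Among the measured compounds shown here, no measured step touches this part of the molecule; the single measured step concerns another group, so it gives no guide to the direction or size of the change in this assay. Because compound 2 is "not active" (no number reported) and compound 1 gives only 20000 nM, compound 4 is expected to give about 25000 nM, within a range of 5000 nM to 100000 nM, and it may well return no number at all.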

Compound 4, half-maximal effective concentration: "not active" (no number reported)
No number was reported for compound 4, so the estimate cannot be set against anything.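

Compound 2 and compound 4 both came back without a number, so no step can be read for pyridin-3-yl in place of pyridin-4-yl, and no evidence bears on this result. As far as these compounds go, whether that swap changes activity at all remains open.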